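The compounds below may be only part of what the source reports. "The series", "measured", "known", "first", "only" and "open" are said of these compounds alone.

Compound 1 `Cc1ccccc1-c1noc(-c2ccc(C3CCCCC3)cc2)n1` gives > 10000 nM in a functional assay on CHO cells with sphingosine 1-phosphate receptor 4 (Homo sapiens) as the target, read by GTPgammaS binding; on this read-out higher numbers stand for an effect only at larger amounts of compound and lower numbers for an effect already at smaller amounts.
Compound 2 `COc1ccc(-c2nc(-c3ccc(CCC(=O)O)cc3C)no2)cc1C(F)(F)F` gives > 10000 nM.
Compound 3 `Cc1cc(CCC(=O)O)ccc1-c1noc(-c2ccc(OC(C)C)c(Cl)c2)n1` gives > 10000 nM.

Each of these three values is a limit of this assay, not a measured number: no effect was seen up to the largest amount of compound tested. Compound 3 therefore stands at the same limit as the other two measured compounds, which is all that the limit of > 10000 nM in this assay, at which 3 of the 3 values shown sit, shows. Among the measured compounds shown here, no two measured compounds differ from each other in only one place, so no measured step is available to guide the next change.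

Compound 4 `COc1cc(-c2nc(-c3ccc(CCC(=O)O)cc3C)no2)ccc1OC(C)C` differs from compound 3 in one place: methoxy in place of chloro on an aromatic carbon. For the measured compounds named here, compound 3 sits at a limit, so no step in this assay can be read from it as a starting point. With three compounds of this kind all at the limit, compound 4 is expected to stay close to that limit as well, estimated at 15000 nM with a range from 3000 nM to 100000 nM. The expected step that this estimate means, a step that the limit leaves unreadable from compound 3 to compound 4, is small, within what a limit can show, and it is likely that only a limit will be reported again.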

Compound 4, half-maximal effective concentration: > 10000 nM
Compound 4 gave a limit, no number (the forecaster's own chance of this, stated with the estimate: 75%); the middle value is on the limit's open side.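

Compound 3 and compound 4 both give a limit rather than a measured number, so no step can be read between them: the limit of > 10000 nM in this assay, at which 4 of the 4 values shown sit. The compounds shown leave open which structural change, if any, would give a measurable value in this assay.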